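Swapping the hydroxynaphthyl end group for a dimethylphenol

The source may hold more compounds than are shown below. What is called first, only, known or untested is meant among the compounds shown, and "the series" means these compounds.

Measured compounds:
compound 1 `COc1ccc(OC)c(/C=N/NC(=O)Nc2ccc(Oc3ccnc(-c4nncn4CCN(C)C)c3)c(F)c2)c1` — 1510 nM
compound 2 `CN(C)CCn1cnnc1-c1cc(Oc2ccc(NC(=O)N/N=C/c3ccc(O)c(F)c3)cc2F)ccn1` — 1970 nM
compound 3 `CN(C)CCn1cnnc1-c1cc(Oc2ccc(NC(=O)N/N=C/c3c(O)ccc4ccccc34)cc2F)ccn1` — 2020 nM

All three were tested in a functional assay on MKN-45 cells (Homo sapiens) for cytotoxicity, read by MTT assay, with a stated time of 72 h; a higher number here means a weaker inhibitor, a lower number a stronger inhibitor. Compound 3 has the highest of the three numbers, but the gaps are small: the step of a 1.0-fold higher number from compound 2 to compound 3 (0.01 log units; within the scatter) is negligible, and the step of a 1.3-fold higher number from compound 1 to compound 3 (0.13 log units; within the scatter) is also within the scatter. The three compounds share one core and differ only in the group attached to the carbon with a double bond to nitrogen, and none of those exchanges moved the number beyond what repeated measurements would show.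

Compound 4 `Cc1cc(/C=N/NC(=O)Nc2ccc(Oc3ccnc(-c4nncn4CCN(C)C)c3)c(F)c2)cc(C)c1O` has not been measured. It differs from compound 3 in one place: 4-hydroxy-3,5-dimethylphenyl in place of 2-hydroxynaphthalen-1-yl on a carbon with a double bond to nitrogen

For the measured compounds named here, the steps that bear on this change are the earlier exchanges at the same position, a 1.3-fold higher number from compound 1 to compound 2 (0.12 log units; within the scatter), a 1.3-fold higher number from compound 1 to compound 3 (0.13 log units; within the scatter) and a 1.0-fold higher number from compound 2 to compound 3 (0.01 log units; within the scatter), each within the scatter. Another aromatic group at this position is therefore expected to leave the number about where it is, with no clear direction. Compound 4 is expected to give 1800 nM, with a likely range from 900 nM to 3600 nM. That estimate means a step of a 1.1-fold lower number from compound 3 to compound 4 (0.05 log units; within the scatter), expected to stay within the scatter.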

Compound 4, half-maximal inhibitory concentration: 1510 nM
Beside the measured number, compound 4's estimate is 1.2-fold (0.08 log units) above it, and the stated range covers the measured number.
By their numbers in this assay, from the lowest: compounds 1, 4, 2 and 3 (each within the scatter of the next).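

The steps of a 1.3-fold lower number from compound 3 to compound 4 (0.13 log units; within the scatter) and a 1.3-fold lower number from compound 2 to compound 4 (0.12 log units; within the scatter) and no change at the digits printed from compound 1 to compound 4 (within the scatter) show in this assay that 4-hydroxy-3,5-dimethylphenyl reads level with all three earlier groups on the carbon with a double bond to nitrogen. The new compound also adds a comparison the earlier ones did not offer: 2-hydroxynaphthalen-1-yl, with its two six-membered aromatic rings of carbon only, gives way to a group with one such ring and two methyl groups, and the number stays within the scatter, so the second ring is not required to keep this reading among these compounds. Nothing measured here accounts for why such different aromatic groups read alike.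

From the compounds shown here alone, all four groups at this position are aromatic rings of carbon that carry oxygen, so the effect of an amine, a carboxylic acid or a plain alkyl chain in their place remains open. Also open is whether a group at this position can move the number beyond the scatter at all, since every exchange shown so far stays within it.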